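The compounds below may be only part of what the source reports. "The series", "measured", "known", "first", "only" and "open" are said of these compounds alone.

Compound 1, `O=C(/C=C/c1ccc2c(c1)B(O)OC2)c1ccco1`, belongs to a small set of related compounds tested in an ADME assay on L929 cells (Mus musculus) for cytotoxicity, read by resazurin assay, with a stated time of 72 h; on this read-out lower numbers stand for stronger inhibition and higher numbers for weaker inhibition. In this test compound 1 gives > 10 ug/mL, which is a limit of the assay and not a number. Compound 2, `O=C(/C=C/c1ccc2c(c1)B(O)OC2)c1ccc([N+](=O)[O-])cc1`, gives > 10 ug/mL, which is also a limit. Compound 3, `COc1ccc(C(=O)/C=C/c2ccc3c(c2)B(O)OC3)c(OC)c1`, is the only one of the three with an actual number, at 7.87 ug/mL. Going by these compounds, compound 1 therefore stands at the limit of > 10 ug/mL in this assay, at which 2 of the 3 values shown sit, so its true position remains open.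

Compound 4, `O=C(/C=C/c1ccc2c(c1)B(O)OC2)c1ccccc1F`, has not yet been measured. It differs from compound 1 in a single place, with 2-fluorophenyl in place of furan-2-yl on a carbonyl carbon. Among the measured compounds shown here, compound 3, at 7.87 ug/mL, is the only numerical guide, so no change beyond the usual scatter is expected, and no direction can be favoured. The estimated step is a number no higher from compound 1 to compound 4 (the limit leaves the size open). For compound 4 the expected value is 10 ug/mL, with an estimated range from 5 ug/mL to 20 ug/mL.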

Compound 4, half-maximal inhibitory concentration: > 10 ug/mL
Compound 4: no number, only a limit (the forecaster's own chance of this, stated with the estimate: 60%); the middle value lies on the limit itself.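

Compound 1 and compound 4 both rest on a limit of the assay and not on a number, so no step can be read between them: the limit of > 10 ug/mL in this assay, at which 3 of the 4 values shown sit.

The compounds shown leave open whether 2-fluorophenyl in place of furan-2-yl changes the result in this assay at all.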